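Sulfonamide nitrogen substituent: cyclobutyl to ethyl

The compounds below may be only part of what the source reports. "The series", "measured", "known", "first", "only" and "open" are said of these compounds alone.

Measured compounds:
- compound 1, `CC(C)NS(=O)(=O)c1ccc(S(=O)(=O)N2CCC[C@@H](C(=O)N3CCN(c4nc(C(C)C)no4)CC3)C2)cc1`: in a functional assay on MIA PaCa-2 cells (Homo sapiens) for inhibition, read by MTT assay, with a stated time of 3 days (a higher number here means a weaker inhibitor, a lower number a stronger inhibitor), compound 1 gives 200 nM
- compound 2, `CC(C)c1noc(N2CCN(C(=O)[C@@H]3CCCN(S(=O)(=O)c4ccc(S(=O)(=O)NC5CCC5)cc4)C3)CC2)n1`: in this assay compound 2 gives 200 nM

Compound 2 stands level with compound 1 on the numbers shown; the step of no change at the digits printed from compound 1 to compound 2 (within the scatter), cyclobutyl in place of isopropyl on a sulfonamide nitrogen, stayed within the scatter. Compound 3, `CCNS(=O)(=O)c1ccc(S(=O)(=O)N2CCC[C@@H](C(=O)N3CCN(c4nc(C(C)C)no4)CC3)C2)cc1`, differs from compound 2 by ethyl in place of cyclobutyl on a sulfonamide nitrogen. For the measured compounds named here, the one measured step bearing on this position is the one from compound 1 to compound 2, and it did not move the read-out beyond the scatter. Going by the values given here, nothing measured so far gives a direction for the exchange of cyclobutyl for ethyl, so the step of a 1.1-fold higher number from compound 2 to compound 3 (0.04 log units; within the scatter) is expected to stay within the scatter. Compound 3 is therefore estimated at 220 nM in this assay, with a range from 100 nM to 500 nM.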

Compound 3, half-maximal inhibitory concentration: 200 nM
Compound 3: middle estimate off by 1.1-fold (0.04 log units), on the high side; low and high end bracket the measured number.
By their numbers in this assay, from the lowest: compounds 1, 2 and 3 (each within the scatter of the next).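

In this assay, ethyl in place of cyclobutyl on the sulfonamide nitrogen gives no change at the digits printed from compound 2 to compound 3 (within the scatter), so the four-membered ring of carbon is not needed to hold the read-out at this position. Hydrogen in place of methyl on the saturated chain carbon, going from isopropyl to ethyl, gives no change at the digits printed from compound 1 to compound 3 (within the scatter), so isopropyl, cyclobutyl and ethyl all read alike here across compound 1, compound 2 and compound 3. No supporting data bear on why these three groups read alike.

Still open, on these data alone, is how far this tolerance extends on the sulfonamide nitrogen, for example to a longer chain such as n-hexyl, or to a chain ending in an amine or a carboxylic acid. As far as these compounds go, all three compounds share the rest of the core, so the response to changes elsewhere also remains open.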